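The source may report more compounds than this note shows. Statements on the series, on what has been measured and on what is new or still open speak of the compounds shown alone.

Measured compounds, with their results in a functional assay on PC-12 cells (Rattus norvegicus) for cytotoxicity, read by MTT assay, with stated times of 3 h and 2 h, tested at 10 uM; a higher number here means a stronger effect of the compound at the concentration tested, a lower number a weaker effect:
compound 2 `O=C(CCCCC1CCSS1)NCc1cn(CCCCCOc2ccc3ccc(=O)oc3c2)nn1` gives 71.3%
compound 3 `Cc1cc(=O)oc2cc(OCCCCCn3cc(CNC(=O)CCCCC4CCSS4)nn3)ccc12` gives 66.3%
compound 1 `O=C(CCCCC1CCSS1)NCc1cn(CCCOc2ccc3cc(-c4ccc(Cl)c(Cl)c4)c(=O)oc3c2)nn1` gives 49.6%

Compound 2 holds the highest of these three numbers, but its nearest neighbour, compound 3, is close enough that the two cannot be told apart, while compound 1 lies clearly lower, beyond the scatter.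

Compound 4 `CC(=O)c1cc2ccc(OCCCCCn3cc(CNC(=O)CCCCC4CCSS4)nn3)cc2oc1=O` has not yet been measured in this assay. It differs from compound 2 in a single place: acetyl in place of hydrogen on an aromatic carbon.

For the measured compounds named here, the only measured step at the same place is the one from compound 2 to compound 3, where a methyl replaced a hydrogen on an aromatic carbon and the result was a number 5 percentage points lower from compound 2 to compound 3 (within the scatter), a change within the scatter. Acetyl is a different group from methyl, so that step is only a rough guide. Going by the values given here, compound 1 is lower than compound 2, but it differs in more than one place, so no single step can be drawn from it.

On this basis the step from compound 2 to compound 4 is expected to be small, a number 6.3 percentage points lower from compound 2 to compound 4 (within the scatter), and may well fall within the scatter. Compound 4 is therefore estimated to give about 65% in this assay, within a range from 45% to 82%.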

Compound 4, a percentage reported as activity, at one concentration (the size of the read-out at that concentration, not a potency): 20.8%
The estimate for compound 4 lay 44.2 percentage points above the measured number; the measured number lies below the stated range.
By their numbers in this assay, from the lowest: compound 4; then compound 1; then compounds 3 and 2 (each within the scatter of the next).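

In this assay the change from hydrogen to acetyl on this aromatic carbon, two atoms from the ring oxygen, gives a number 50.5 percentage points lower from compound 2 to compound 4 (beyond the scatter) and so moves the read-out far. The earlier compounds shown here offered only a number 5 percentage points lower from compound 2 to compound 3 (within the scatter) for a methyl on an aromatic carbon, so they gave no sign that adding a substituent to this part of the shared core could matter this much; here an addition of just 3 heavy atoms, with one double bond outside the aromatic rings and one hydrogen-bond acceptor, is enough. Nothing shown here accounts for the size of this step, and its cause stays unknown.

The compounds shown leave open whether the large step belongs to the acetyl group itself or would also appear with other groups on this same carbon, such as a plain methyl, a nitrile, a methyl ester or a carboxylic acid. They also leave open whether acetyl would have a step of similar size with a longer or shorter chain joining the core to the triazole side.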